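Swapping one ring on a long ester chain

The compounds below may be only part of what the source reports. "The series", "measured", "known", "first", "only" and "open" are said of these compounds alone.

- Compound 1 (`CCOC(=O)/C=C/C=C/C=C/C=C/c1cccn1C`): > 10000 nM (a limit)
- Compound 2 (`CCOC(=O)/C=C/C=C/C=C/C=C/c1nccs1`): > 10000 nM (a limit)

In a functional assay on CCRF-CEM cells (Homo sapiens) for cytotoxicity, with a stated time of 72 h (a higher number here means a weaker inhibitor, a lower number a stronger inhibitor), compound 2 gives > 10000 nM as a limit, not a number. For the measured compounds named here, the picture so far is the limit of > 10000 nM in this assay, at which 2 of the 2 values shown sit, and the one measured step is a step that the two limits leave unreadable from compound 1 to compound 2 so it offers no size to carry over. The change to compound 3 (`CCOC(=O)/C=C/C=C/C=C/C=C/c1ccco1`) is furan-2-yl in place of 1,3-thiazol-2-yl on a double-bonded chain carbon bound to a double-bonded chain carbon and it swaps one five-membered aromatic ring for another. No step beyond the scatter is expected in this assay and compound 3 will probably read as a limit too. The expected step is a step that the limit leaves unreadable from compound 2 to compound 3 as an estimate only. For compound 3 the estimated value is 15000 nM with an expected range of 6000 nM to 40000 nM as the likely span.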

Compound 3, half-maximal inhibitory concentration: > 10000 nM
Compound 3: a limit, no number (the forecaster's own chance of this, stated with the estimate: 75%); the middle value does not contradict the limit.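

For the compounds shown here, compound 1, compound 2 and compound 3 each give only a limit in this assay, so no step between them can be read. From the compounds shown here alone, whether their three rings differ at all in cytotoxicity remains open.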